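Shifting the thiophene attachment point in compound 2

This account rests on a few compounds, and the source may have more. Where it says the series, first, only, none or still open, it means among the compounds named here.

Compound 1 `COC(=O)C1=C(C)N(C)C(=O)NC1c1cccs1`: 30%
Compound 2 `CC1=C(C(=O)OC(C)(C)C)C(c2cccs2)NC(=O)N1C`: 18%
Compound 3 `CC1=C(C(=O)OCc2ccccc2)C(c2cccs2)NC(=O)N1C`: 50%

In an assay on membranes from CHO cells for displacement of a labelled ligand from adenosine receptor A1 (Homo sapiens), read by scintillation counting, with a stated time of 60 min, tested at 1 uM (a lower number here means less inhibition, a higher number more inhibition at the concentration tested (going by the name of the read-out)), compound 2 gives the lowest of the three numbers. The step of a number 12 percentage points lower from compound 1 to compound 2 (beyond the scatter) and the step of a number 32 percentage points higher from compound 2 to compound 3 (beyond the scatter) both lie beyond the scatter. Compound 4 `CC1=C(C(=O)OC(C)(C)C)C(c2ccsc2)NC(=O)N1C` keeps the tert-butyl ester of compound 2 and changes only the aromatic ring: thiophen-3-yl in place of thiophen-2-yl on a saturated ring carbon. For the measured compounds named here, every measured step here alters the group on the oxygen next to the carbonyl; none touches the thiophene, so no measured step bears directly on this change. With nothing to point either way, the expected change is none beyond the scatter, as no change at the digits printed from compound 2 to compound 4 (within the scatter). Compound 4 is therefore estimated at 18%, with a range from 5% to 35%.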

Compound 4, a percentage reported as inhibition, at one concentration (the size of the read-out at that concentration, not a potency): 18%
Beside the measured number, compound 4's estimate shows no gap at the digits printed, and the stated range covers the measured number.
By their numbers in this assay, from the lowest: compounds 2 and 4 (each within the scatter of the next); then compound 1; then compound 3.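

In this assay, for the compounds shown here, thiophen-3-yl in place of thiophen-2-yl on the saturated ring carbon gives no change at the digits printed from compound 2 to compound 4 (within the scatter) and is the only measured step that touches this ring rather than the ester. With the tert-butyl ester held fixed, the attachment point of the thiophene therefore leaves the read-out unmoved, while each listed change on the ester oxygen moved it beyond the scatter. No evidence on hand accounts for this result. On these data alone, whether the same swap would stay as quiet with the benzyl ester of compound 3 remains open. So does the effect of a phenyl ring, or of an amine on the thiophene, at this ring carbon.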